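The source may hold more compounds than are shown below. What is called first, only, known or untested is meant among the compounds shown, and "the series" means these compounds.

Among the measured compounds shown here, in an ADME assay on CCRF-CEM cells (Homo sapiens) for cytotoxicity, with a stated time of 4 days (on this read-out lower numbers stand for higher toxicity in this test and higher numbers for lower toxicity in this test), compound 1 (`Cc1cn([C@@H]2O[C@H](CO[Si](C)(C)C(C)(C)C)[C@@]3(OS(=O)(=O)C=C3N)[C@H]2O[Si](C)(C)C(C)(C)C)c(=O)n(C(=O)c2ccccc2)c1=O`) gives 54000 nM and compound 2 (`Cc1cn([C@@H]2O[C@H](CO[Si](C)(C)C(C)(C)C)[C@@]3(OS(=O)(=O)C=C3N)[C@H]2O[Si](C)(C)C(C)(C)C)c(=O)n(C(=O)CCCC(=O)N(C)C)c1=O`) gives 9500 nM as the lower of the two numbers so far. Compound 3 (`Cc1cn([C@@H]2O[C@H](CO[Si](C)(C)C(C)(C)C)[C@@]3(OS(=O)(=O)C=C3N)[C@H]2O[Si](C)(C)C(C)(C)C)c(=O)n(C(=O)CCCC(=O)OC(C)(C)C)c1=O`) shares the core of compound 2 and differs from it in one place, with tert-butoxy in place of dimethylamino on a carbonyl carbon. For the measured compounds named here, the only measured step, a 5.7-fold lower number from compound 1 to compound 2 (0.75 log units; beyond the scatter) for 3-(dimethylcarbamoyl)propyl in place of phenyl on a carbonyl carbon, was modest but beyond the scatter. That step exchanged the whole group, whereas the new change only turns dimethylcarbamoyl into tert-butoxycarbonyl. No measurement covers this exchange directly, so no step beyond the scatter and no firm direction is expected. The estimate means a 1.2-fold higher number from compound 2 to compound 3 (0.06 log units; within the scatter) as the expected step in this assay for this change. For compound 3 the estimated value is 11000 nM (expected range 4000 nM to 30000 nM).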

Compound 3, half-maximal cytotoxic concentration: 11000 nM
Estimate against measurement, compound 3: no gap at the digits printed; the measured number falls inside the stated range.
By their numbers in this assay, from the lowest: compounds 2 and 3 (each within the scatter of the next); then compound 1.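

In this assay, tert-butoxy in place of dimethylamino on a carbonyl carbon gives a 1.2-fold higher number from compound 2 to compound 3 (0.06 log units; within the scatter), so the two end groups cannot be told apart at this position. The second new comparison, 3-(tert-butoxycarbonyl)propyl in place of phenyl on a carbonyl carbon, gives a 4.9-fold lower number from compound 1 to compound 3 (0.69 log units; beyond the scatter), so the lower number is not confined to the dimethylcarbamoyl chain of compound 2 and also appears with the tert-butoxycarbonyl chain of compound 3. Among these three compounds, the number therefore moves beyond the scatter when phenyl is replaced, but not when the end of the chain is exchanged. The compounds shown leave open whether a free carboxylic acid, a primary amide or a longer chain at this place would give a number in the same range. No measurement available here explains these results.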